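Halogen shift on the aryl hydrazide of compound 3

The source may hold more compounds than are shown below. What is called first, only, known or untested is meant among the compounds shown, and "the series" means these compounds.

Three compounds of one series were measured in an assay on HeLa cells for inhibition of Indoleamine 2,3-dioxygenase 1 (Homo sapiens), read by spectrophotometry, with a stated time of 24 h; a higher number here means that more compound is needed for the effect, a lower number that less compound is needed. Compound 1 `CC(=O)Nc1ccc(S(=O)(=O)NNc2ccccc2)cc1` has an unsubstituted phenyl on the amine nitrogen; in this assay compound 1 gives only a limit, > 10000 nM (the limit of > 10000 nM in this assay, at which 1 of the 3 values shown sits). Compound 2 `CC(=O)Nc1ccc(S(=O)(=O)NNc2ccc(C)cc2)cc1` gives 1170 nM in this assay. Compound 3 `CC(=O)Nc1ccc(S(=O)(=O)NNc2ccc(Cl)cc2)cc1` gives 142 nM in this assay, the lowest of the two numbers shown, with compound 2 as its nearest neighbour. The measured steps are an at least 8.5-fold lower number from compound 1 to compound 2 (0.93 log units; beyond the scatter), an at least 70-fold lower number from compound 1 to compound 3 (1.84 log units; beyond the scatter) and an 8.2-fold lower number from compound 2 to compound 3 (0.92 log units; beyond the scatter).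

Compound 4 `CC(=O)Nc1ccc(S(=O)(=O)NNc2cccc(Br)c2)cc1` is not yet measured. It differs from compound 3 by 3-bromophenyl in place of 4-chlorophenyl on an amine nitrogen. Within the data shown here, the steps of an at least 70-fold lower number from compound 1 to compound 3 (1.84 log units; beyond the scatter) and an 8.2-fold lower number from compound 2 to compound 3 (0.92 log units; beyond the scatter) show how much a halogen on that ring lowered the number, but no measured step moves a halogen around the ring or exchanges chloro for bromo, so this change is not covered directly. Compound 4 keeps a halogen on the ring, and a loss as large as the gap of an at least 70-fold lower number from compound 1 to compound 3 (1.84 log units; beyond the scatter) is therefore not expected, though a rise in the number beyond the scatter is estimated as likely. Compound 4 is expected to give about 450 nM in this assay, within 110 nM to 2000 nM. This expectation corresponds to a 3.2-fold higher number from compound 3 to compound 4 (0.50 log units; beyond the scatter).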

Compound 4, half-maximal effective concentration: 7560 nM
Compound 4: the middle estimate sits 17-fold (1.23 log units) below what was measured; measured number outside the range, above it.
By their numbers in this assay, from the lowest: compound 3; then compound 2; then compound 4. At a limit, above all of these: compound 1.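

In this assay, 3-bromophenyl in place of 4-chlorophenyl on an amine nitrogen gives a 53-fold higher number from compound 3 to compound 4 (1.73 log units; beyond the scatter), so keeping a halogen on this ring does not by itself keep the number low, something the earlier measurements could not show. The same ring also compares poorly with 4-methylphenyl, with a 6.5-fold higher number from compound 2 to compound 4 (0.81 log units; beyond the scatter), so the advantage of chloro over methyl seen earlier does not extend to every halogen-bearing ring at this nitrogen. With an at least 1.3-fold lower number from compound 1 to compound 4 (0.12 log units; that floor lies within the scatter), the data do not say whether bromo on the ring lowers the number at all relative to the unsubstituted phenyl. Compound 1 gives only a limit: the limit of > 10000 nM in this assay, at which 1 of the 4 values shown sits.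

The single step from compound 3 to compound 4 changes both the halogen and its place on the ring, so the compounds shown leave open which of the two accounts for the rise. They also leave open how this nitrogen's aryl ring would respond to groups of another kind, such as a nitrile or a trifluoromethyl group.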